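From methyl ester to alcohol on the amine chain

A few compounds are considered here, and "the series" means these few. Any claim that something is new, unique, unknown or untested is made for them only; others in the source may bear on it.

In a functional assay on MCF7 cells (Homo sapiens) for antiproliferative activity (on this read-out lower numbers stand for stronger inhibition and higher numbers for weaker inhibition), compound 1 `CCN(CC)CCCOc1ccc2cc(NC(=O)c3ccc(O)c(CC=C(C)C)c3)c(=O)oc2c1C` gives 6390 nM while compound 2 `CC(C)=CCc1cc(C(=O)Nc2cc3ccc(OCCCN(C)C(C)(C)C)c(C)c3oc2=O)ccc1O` gives 1140 nM and compound 3 `COC(=O)CNCCCOc1ccc2cc(NC(=O)c3ccc(O)c(CC=C(C)C)c3)c(=O)oc2c1C` gives 2820 nM as its value. Compound 3 therefore holds the middle place among the three numbers. Compound 4 `CC(C)=CCc1cc(C(=O)Nc2cc3ccc(OCCCNCCO)c(C)c3oc2=O)ccc1O` has not yet been measured. Its difference from compound 3 is hydroxymethyl in place of methoxycarbonyl on a saturated chain carbon bound to an amine nitrogen and amounts to hydroxymethyl in place of methoxycarbonyl on a saturated chain carbon bound to an amine nitrogen. Within the data shown here, no measured step makes this exact change. The closest evidence comes from swapping the amine on the same chain, which gave a 2.3-fold lower number from compound 1 to compound 3 (0.36 log units; beyond the scatter) and a 5.6-fold lower number from compound 1 to compound 2 (0.75 log units; beyond the scatter) and a 2.5-fold higher number from compound 2 to compound 3 (0.39 log units; beyond the scatter) as its moves. All three are modest, though beyond the scatter, and none indicates a direction for the new group. Little movement in this assay is therefore expected, with no step beyond the scatter. The expected change is a 1.1-fold higher number from compound 3 to compound 4 (0.03 log units; within the scatter) on this estimate. For compound 4 the estimated value is 3000 nM with an expected range from 1200 nM to 7500 nM overall.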

Compound 4, half-maximal inhibitory concentration: 1560 nM
Compound 4: the middle estimate sits 1.9-fold (0.28 log units) above what was measured, and the stated range covers the measured number.
By their numbers in this assay, from the lowest: compounds 2, 4 and 3 (each within the scatter of the next, the first and the last beyond it); then compound 1.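

Swapping the ester for the alcohol at this place, hydroxymethyl in place of methoxycarbonyl on a saturated chain carbon bound to an amine nitrogen, gives a 1.8-fold lower number from compound 3 to compound 4 (0.26 log units; within the scatter) in this assay and so leaves the read-out within the scatter, which means the methyl ester is not required for this level of activity. The (2-hydroxyethyl)amino chain also gives a 1.4-fold higher number from compound 2 to compound 4 (0.14 log units; within the scatter) and cannot be told apart from methyl(tert-butyl)amino, while it keeps a clear gain over diethylamino with a 4.1-fold lower number from compound 1 to compound 4 (0.61 log units; beyond the scatter) on the same read-out. Nothing measured here explains these results.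

The compounds shown leave open how a carboxylic acid or a primary amide would read at this place. They also leave open whether a longer chain such as 3-hydroxypropyl on the amine nitrogen would hold this level.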